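Notes on compound 4 within the shared-core hydrazone series

This account rests on a few compounds, and the source may have more. Where it says the series, first, only, none or still open, it means among the compounds named here.

Compound 1 `CCCSc1nc(N/N=C/c2ccccc2F)c2nnn(Cc3ccccc3)c2n1` reaches only the assay limit > 64000 nM in a functional assay on MCF7 cells (Homo sapiens) for antiproliferative activity, read by MTT assay, with a stated time of 72 h; on this read-out lower numbers stand for stronger inhibition and higher numbers for weaker inhibition.
Compound 2 `CCCSc1nc(N/N=C/c2ccc(Cl)cc2)c2nnn(Cc3ccccc3)c2n1` reaches only the assay limit > 64000 nM.
Compound 3 `CCCSc1nc(N/N=C(\C)c2ccc(O)cc2)c2nnn(Cc3ccccc3)c2n1` gives 21600 nM.

Among the compounds with values here, compound 3 holds the only number in the set; the other two values are limits (the limit of > 64000 nM in this assay, at which 2 of the 3 values shown sit). Compound 4 `CCCSc1nc(N/N=C/c2cccc(Cl)c2)c2nnn(Cc3ccccc3)c2n1` differs from compound 3 by a group of 9 heavy atoms (7 carbon, 1 nitrogen, 1 chlorine; one six-membered aromatic ring of carbon only) in place of a group of 10 heavy atoms (8 carbon, 1 nitrogen, 1 oxygen; one six-membered aromatic ring of carbon only), on a nitrogen on an aromatic ring. The measured steps that bear on this are an at least 2.9-fold lower number from compound 1 to compound 3 (0.47 log units; beyond the scatter) and an at least 2.9-fold lower number from compound 2 to compound 3 (0.47 log units; beyond the scatter), both reaching compound 3 from a halogen-bearing group of 9 heavy atoms. Compound 4 carries such a group again, so the step is expected to run the other way, with a higher number that may return to the limit. For compound 4 the expected step is a 3.0-fold higher number from compound 3 to compound 4 (0.47 log units; beyond the scatter). Compound 4 is therefore estimated at 64000 nM, within 30000 nM to 200000 nM.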

Compound 4, half-maximal inhibitory concentration: > 64000 nM
Compound 4: only a limit was reported; the forecaster's own chance of this, stated with the estimate: 65%; the middle value sits exactly at the limit.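

In this assay the change gives an at least 2.9-fold higher number from compound 3 to compound 4 (0.47 log units; beyond the scatter), with a chlorine-bearing group of 0 hydrogen-bond donors replacing the group with 1 donor. A third halogen-bearing group now sits with compound 1 and compound 2 at the same limit: the limit of > 64000 nM in this assay, at which 3 of the 4 values shown sit.

The steps among compound 1, compound 2 and compound 4 join two limits and cannot be read. The change from compound 3 to compound 4 alters the oxygen, the chlorine and the carbon count together, and the compounds shown do not separate these. Going by these compounds, whether an amine on the aromatic ring would give a readable number also stays open.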